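Cyclopentyl for Butyl: Awaiting the Next Read-out

The compounds below may be only part of what the source reports. "The series", "measured", "known", "first", "only" and "open" are said of these compounds alone.

The three measured compounds in a functional assay on HCT-116 cells (Homo sapiens) for antiproliferative activity, read by CCK-8 assay, with a stated time of 72 h, tested at 8 uM; on this read-out lower numbers stand for a weaker effect and higher numbers for a stronger effect at the one concentration tested:
compound 1 `CCCCn1cnc2c(Nc3ccccc3)nc(NCOCc3ccc(/C=C/C(=O)Nc4ccccc4N)cc3)nc21` gives 51.9%;
compound 2 `Nc1ccccc1NC(=O)c1ccc(Cn2cnc3c(Nc4ccccc4)nc(Cl)nc32)cc1` gives 83.5%;
compound 3 `CCCCn1cnc2c(Nc3cccc(Cl)c3)nc(NCOCc3ccc(/C=C/C(=O)Nc4ccccc4N)cc3)nc21` gives 10.9%.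

Compound 3 stands lowest of the three. Its nearest neighbour is compound 1, reached by a number 41 percentage points lower from compound 1 to compound 3 (beyond the scatter); compound 2 lies furthest from it, with both values shown above.

Compound 4 `Nc1ccccc1NC(=O)/C=C/c1ccc(COCNc2nc(Nc3cccc(Cl)c3)c3ncn(C4CCCC4)c3n2)cc1` differs from compound 3 by cyclopentyl in place of butyl on an aromatic nitrogen. Among the compounds with values here, the only measured step concerns a chloro in place of hydrogen on an aromatic carbon, so no measured step bears on the change made here. The expectation therefore leans on compound 3 alone: compound 4 is expected to show a step of a number 4.1 percentage points higher from compound 3 to compound 4 (within the scatter) in this assay, that is, none beyond the scatter. Compound 4 is estimated at 15%, within 0% to 40%.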

Compound 4, a percentage reported as inhibition, at one concentration (the size of the read-out at that concentration, not a potency): 9.19%
Beside the measured number, compound 4's estimate is 5.8 percentage points above it, and the stated range covers the measured number.
By their numbers in this assay, from the lowest: compounds 4 and 3 (each within the scatter of the next); then compound 1; then compound 2.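

In this assay, cyclopentyl in place of butyl on an aromatic nitrogen gives a number 1.7 percentage points lower from compound 3 to compound 4 (within the scatter). The ring nitrogen therefore carries a five-membered non-aromatic ring of carbon only as well as an open butyl chain with no difference beyond the scatter, at least while the chloro group is present. No available evidence accounts for this result.

As far as these compounds go, whether cyclopentyl gives the same result without the chloro group remains open. So does the effect of a longer chain or an amine-bearing chain on that nitrogen.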